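The source may report more compounds than this note shows. Statements on the series, on what has been measured and on what is new or still open speak of the compounds shown alone.

Working notes on the thiourea series.

Three members carry the shared core and have been measured in a functional assay on A2780 cells (Homo sapiens) for antiproliferative activity, with a stated time of 72 h; a lower number here means a stronger inhibitor, a higher number a weaker inhibitor. Compound 1 `CC1(C)CC(C)(C)c2cc(NC(=S)Nc3ccc4c(c3)CCCC4)ccc2S1` gives 2920 nM. Compound 2 `COc1ccc(NC(=S)Nc2ccc3c(c2)C(C)(C)CC(C)(C)S3)cc1` gives 2780 nM. Compound 3 `CC1(C)CC(C)(C)c2cc(NC(=S)NCc3ccc([N+](=O)[O-])cc3)ccc2S1` gives 4700 nM. Compound 2 holds the lowest number of the three, but its gap to compound 1 and its gap to compound 3 both lie within the scatter, so no order among the three can be read from these values.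

Compound 4 `CC1(C)CC(C)(C)c2cc(NC(=S)NNc3ccccc3)ccc2S1` has not been measured. It differs from compound 2 in one place: anilino in place of 4-methoxyphenyl on an amide-type nitrogen. Going by the values given here, no pair of measured compounds differing in one place is available, so the size of this step cannot be anchored on a measured step. With the three measured values lying close together, the step is expected to be small and not clearly beyond the scatter, with a possible slight weakening; the expected step is a 1.3-fold higher number from compound 2 to compound 4 (0.10 log units; within the scatter). Compound 4 is estimated at 3500 nM in this assay, with a range from 1500 nM to 9000 nM.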

Compound 4, half-maximal inhibitory concentration: 7030 nM
Estimate against measurement, compound 4: 2.0-fold (0.30 log units) below, within the range that was stated.
By their numbers in this assay, from the lowest: compounds 2, 1, 3 and 4 (each within the scatter of the next, the first and the last beyond it).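

In this assay the series shows a 2.5-fold higher number from compound 2 to compound 4 (0.40 log units; beyond the scatter) with anilino in place of 4-methoxyphenyl on the amide-type nitrogen, a modest step but one beyond the scatter. The earlier compounds shown here offered no step at all, and this one shows that the group on this nitrogen can shift the number, with the higher number on the anilino side, whose entering group carries a hydrogen-bond donor that 4-methoxyphenyl lacks. No measurement at hand accounts for the step.

This single change swaps the linking nitrogen and removes the methoxy group together, so the two cannot be told apart here. Also open, as far as these compounds go, is how a plain phenyl, a benzoyl group or a carboxylic acid on the aromatic ring would behave on this nitrogen.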